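The source may report more compounds than this note shows. Statements on the series, on what has been measured and on what is new or still open speak of the compounds shown alone.

The account concerns compound 1, `CS/C(=N\C(=O)c1ccno1)NC(=O)c1ccno1`, in a functional assay on HepG2 cells (Homo sapiens) for cytotoxicity, read by MTT assay, with a stated time of 72 h; on this read-out higher numbers stand for weaker inhibition of growth and lower numbers for stronger inhibition of growth. In this assay compound 1 gives only a limit, > 100000 nM, and not a number. Compound 2, `CS/C(=N\C(=O)c1ccco1)NC(=O)c1ccco1`, likewise reaches only a limit in this assay, > 100000 nM. Both values therefore sit at the same point, namely (the limit of > 100000 nM in this assay, at which 2 of the 2 values shown sit); on the numbers shown compound 1 cannot be separated from compound 2, and no step between measured compounds can be given. The unmeasured compound 3, `O=C(/N=C(/NC(=O)c1ccno1)[Se]Cc1ccccc1)c1ccno1`, differs from compound 1 in one place: a group of 8 heavy atoms (7 carbon, 1 selenium; one six-membered aromatic ring of carbon only) in place of a group of 2 heavy atoms (1 carbon, 1 sulfur; no ring), on a carbon with a double bond to nitrogen, in words a group of 8 heavy atoms (7 carbon, 1 selenium; one six-membered aromatic ring of carbon only) in place of a group of 2 heavy atoms (1 carbon, 1 sulfur; no ring), on a carbon with a double bond to nitrogen. Going by the values given here, with no measured step to lean on, the expected step from compound 1 to compound 3 in this assay is an at least 1.4-fold lower number from compound 1 to compound 3 (0.15 log units; that floor lies within the scatter), a modest move toward stronger growth inhibition that may not leave the scatter. Compound 3 is thus estimated at 70000 nM, in the range 15000 nM to 300000 nM, with a real chance that this assay again reports only a limit for it.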

Compound 3, concentration for total growth inhibition: 58900 nM
Compound 3: the middle estimate sits 1.2-fold (0.07 log units) above what was measured; the range from low to high includes it.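

In this assay, exchanging methylsulfanyl for the group of 8 heavy atoms (7 carbon, 1 selenium; one six-membered aromatic ring of carbon only), on a carbon with a double bond to nitrogen whose other neighbours are two amide-type nitrogens, gives an at least 1.6-fold lower number from compound 1 to compound 3 (0.22 log units; that floor lies within the scatter). Going by these compounds alone, this place therefore accepts a much larger group carrying a six-membered aromatic ring of carbon only, and the read-out returns a number rather than a limit, which the earlier compounds did not show, although with the floor of the step within the scatter, a real gain in growth inhibition is not established. The true size of the step cannot be read because compound 1 stands at a limit: the limit of > 100000 nM in this assay, at which 2 of the 3 values shown sit.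

The change alters the atom attached to this carbon and the group carried on that atom together, so the compounds shown do not separate the contribution of selenium from that of the aromatic ring, which a methylselanyl or a benzylsulfanyl group at this place would address. As far as these compounds go, how an amine at the same place would read in this assay also remains open.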